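A few compounds are considered here, and "the series" means these few. Any claim that something is new, unique, unknown or untested is made for them only; others in the source may bear on it.

In a functional assay on SK-MEL-28 cells (Homo sapiens) for cytotoxicity, read by MTT assay, with a stated time of 3 days (a higher number here means a weaker inhibitor, a lower number a stronger inhibitor), compound 1 `N#Cc1c(O)nc(SCc2nc3ccccc3[nH]2)nc1-c1ccccc1` gives 7.7 nM and compound 2 `N#Cc1c(Cl)nc(SCc2nc3ccccc3[nH]2)nc1-c1ccccc1` gives 3.28 nM, the lower of the two numbers. Compound 3 `N#Cc1c(NN)nc(SCc2nc3ccccc3[nH]2)nc1-c1ccccc1` differs from compound 2 by aminoamino in place of chloro on an aromatic carbon, with aminoamino in place of chloro on an aromatic carbon, ortho to a cyano group. Within the data shown here, the one measured step that bears on this is modest: a 2.3-fold lower number from compound 1 to compound 2 (0.37 log units; beyond the scatter), with chloro in place of hydroxy at that carbon. Among the measured compounds shown here, with only that step as a guide, a similarly modest rise in the number is expected as chloro leaves, an estimated 2.1-fold higher number from compound 2 to compound 3 (0.33 log units; beyond the scatter). For compound 3 the estimate is 7 nM, within an expected range of 2 nM to 25 nM.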

Compound 3, half-maximal inhibitory concentration: 3 nM
Compound 3: middle estimate off by 2.3-fold (0.37 log units), on the high side; the measured number falls inside the stated range.
By their numbers in this assay, from the lowest: compounds 3 and 2 (each within the scatter of the next); then compound 1.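

In this assay, the step of a 1.1-fold lower number from compound 2 to compound 3 (0.04 log units; within the scatter) shows that this carbon, ortho to a cyano group, accepts aminoamino in place of chloro with no change beyond the scatter, even though the entering group has hydrogen-bond donors and the leaving group has none. The step of a 2.6-fold lower number from compound 1 to compound 3 (0.41 log units; beyond the scatter) with aminoamino in place of hydroxy leaves compound 1 as the only one of the three that stands apart. Nothing measured here explains this result.

Going by these compounds, whether a plain amine, a methoxy group or a longer chain at this carbon would keep the number in this range remains open.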